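Trimming the Benzyl Ether Down to an Ethyl Ether

This account rests on a few compounds, and the source may have more. Where it says the series, first, only, none or still open, it means among the compounds named here.

Compound 1 `CN(C)CCNc1ccnc2cc(OCc3ccccc3)ccc12` gives 2350 nM in a functional assay on RKO cells (Homo sapiens) for cytotoxicity, read by MTT assay, with a stated time of 48 h; a higher number here means a weaker inhibitor, a lower number a stronger inhibitor. For the measured compounds named here, of the three compounds measured so far it holds the second highest number: its nearest neighbour is compound 2 `Clc1ccnc2cc(OCc3ccccc3)ccc12`, which gives 2410 nM, and the furthest is compound 3 `Clc1ccnc2cc(OCCCc3ccccc3)ccc12`, which gives 1420 nM. Going by the values given here, the single step between measured compounds that differ in one place is a 1.0-fold higher number from compound 1 to compound 2 (0.01 log units; within the scatter), and it lies within the scatter.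

Compound 4 `CCOc1ccc2c(NCCN(C)C)ccnc2c1` differs from compound 1 by methyl in place of phenyl on a saturated chain carbon bound to an oxygen on an aromatic ring. Among the compounds with values here, no measured step touches this part of the molecule. The step of a 1.0-fold higher number from compound 1 to compound 2 (0.01 log units; within the scatter) alters the other substituent on the shared core and therefore bears on it only indirectly, showing that the core tolerates a change elsewhere without a shift beyond the scatter. Compounds 2 and 3 differ in the length of the chain between the ether oxygen and the phenyl ring, and their two numbers lie within the scatter of each other, so the ether side chain has so far shown little leverage in this assay.

On that basis, the step from compound 1 to compound 4 is estimated to be a 1.3-fold higher number from compound 1 to compound 4 (0.11 log units; within the scatter), without a clear direction beyond the scatter. Compound 4 is accordingly expected to give about 3000 nM in this assay, with a likely range from 1200 nM to 8000 nM.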

Compound 4, half-maximal inhibitory concentration: 3650 nM
Compound 4: the middle estimate sits 1.2-fold (0.09 log units) below what was measured, and the stated range covers the measured number.
By their numbers in this assay, from the lowest: compounds 3, 1, 2 and 4 (each within the scatter of the next, the first and the last beyond it).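

In this assay, for the compounds shown here, the change from benzyloxy to ethoxy, with methyl in place of phenyl on a saturated chain carbon bound to an oxygen on an aromatic ring, gives a 1.6-fold higher number from compound 1 to compound 4 (0.19 log units; within the scatter) and so provides the first direct reading at this position. The earlier compounds shown here touched this side of the molecule only through a chain-length difference, whereas this pair removes the six-membered aromatic ring altogether and leaves the rest of compound 1 unchanged. Even so, the number stays within the scatter, so this pair does not show that the phenyl ring is needed for the cytotoxicity read here, and nothing available on these compounds explains the result.

Going by these compounds, it remains open whether any group at this position can move the number beyond the scatter, for instance a hydroxyl, an amine or a carboxylic acid carried at the end of the ethyl chain, or a longer alkyl chain without the phenyl ring. On these data alone, the exchange of (2-(dimethylamino)ethyl)amino for chloro has also been read only with the benzyl ether in place, so its size alongside the ethoxy group is still unknown.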